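The source may hold more compounds than are shown below. What is called first, only, known or untested is meant among the compounds shown, and "the series" means these compounds.

The measured compounds:

compound 1, `O=C(COc1c(-c2ccccc2)oc2ccccc2c1=O)Nc1ccccc1`: > 10000 nM
compound 2, `COc1ccc(NC(=O)COc2ccc3oc(-c4ccccc4)cc(=O)c3c2)cc1`: 710 nM
compound 3, `O=C(COc1ccc2c(=O)cc(-c3ccccc3)oc2c1)Nc1ccccc1`: > 10000 nM

In a functional assay on NPC-TW01 cells (Homo sapiens) for antiproliferative activity, read by MTT assay, with a stated time of 72 h (on this read-out higher numbers stand for weaker inhibition of growth and lower numbers for stronger inhibition of growth), compound 3 gives > 10000 nM, which is a limit of the assay and not a number. Compound 1 likewise gives > 10000 nM, also a limit. Among the compounds with values here, compound 2 gives 710 nM, the one value that is a number here. Compound 3 thus stands at the limit of > 10000 nM in this assay, at which 2 of the 3 values shown sit, together with compound 1, while compound 2 stands clearly inside the measurable range.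

Compound 4, `O=C(COc1ccc2c(=O)cc(-c3ccccc3)oc2c1)Nc1ccc(-c2ccccc2)cc1`, differs from compound 3 by phenyl in place of hydrogen on an aromatic carbon. Within the data shown here, no pair among the measured compounds shows such a step. Because compound 2, with a substituted anilide, gives 710 nM, a substituted anilide can reach measurable inhibition, so a move toward stronger inhibition is expected for compound 4, of the size an at least 2.0-fold lower number from compound 3 to compound 4 (0.30 log units; that floor lies within the scatter). Compound 4 is estimated at 5000 nM, within 1000 nM to 20000 nM.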

Compound 4, concentration for 50% growth inhibition: 1610 nM
The estimate for compound 4 lay 3.1-fold (0.49 log units) above the measured number, within the range that was stated.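

In this assay, phenyl on this aromatic carbon, para to a large group, gives an at least 6.2-fold lower number from compound 3 to compound 4 (0.79 log units; beyond the scatter). Within the data shown here, this is the first single change seen here, and it shows that this position accepts a whole extra ring while growth inhibition becomes stronger. The full size of the step stays unknown because compound 3 has only a limit of the assay as its value: the limit of > 10000 nM in this assay, at which 2 of the 4 values shown sit.

Still open, as far as these compounds go, is whether a methyl group, a chlorine atom, an amine or a carboxylic acid at this position would act like phenyl. Also open, from the compounds shown here alone, is whether phenyl here would have the same effect on the core of compound 1.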